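Short alkynyl esters of the shared core: chain length

This account rests on a few compounds, and the source may have more. Where it says the series, first, only, none or still open, it means among the compounds named here.

Measured so far:
compound 1 `C#CCCCOC(=O)Cn1cnc2c1c(=O)n(C)c(=O)n2C` — 162000 nM in a functional assay on MCF7 cells (Homo sapiens) for cytotoxicity, read by MTT assay, with a stated time of 48 h; a higher number here means a weaker inhibitor, a lower number a stronger inhibitor
compound 2 `CCn1c(=O)ccn(C2OC(Cn3cc(COC(=O)Cn4cnc5c4c(=O)n(C)c(=O)n5C)nn3)C(O)C2O)c1=O` — 1890 nM

Compound 1 gives the highest of the two numbers; compound 2 sits well beyond the scatter with the lower number. Compound 3 `C#CCCOC(=O)Cn1cnc2c1c(=O)n(C)c(=O)n2C` is not yet measured. It differs from compound 1 by ethynyl in place of propargyl on a saturated chain carbon, two bonds along the chain from an oxygen next to a carbonyl group. Going by the values given here, no step between measured compounds covers this kind of change, so the expectation rests on compound 1 alone: the step from compound 1 to compound 3 is expected to be small, a 1.0-fold lower number from compound 1 to compound 3 (0.01 log units; within the scatter), with no clear direction. Compound 3 is therefore estimated at 160000 nM, in the range 60000 nM to 450000 nM.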

Compound 3, half-maximal inhibitory concentration: 56300 nM
Estimate against measurement, compound 3: 2.8-fold (0.45 log units) above, outside the stated range (below it).
By their numbers in this assay, from the lowest: compound 2; then compound 3; then compound 1.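

Shortening the chain from pent-4-yn-1-yl to but-3-yn-1-yl, with the triple bond kept, gives a 2.9-fold lower number from compound 1 to compound 3 (0.46 log units; beyond the scatter) in this assay as a modest change. This saturated chain position therefore responds to chain length alone, and the shorter of these two alkynyl esters gives the lower number. No measurement on hand accounts for this step.

Two chain lengths do not establish a trend. From the compounds shown here alone, whether a chain longer than pent-4-yn-1-yl, or an amine in place of the alkyne, would continue this direction remains open.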